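This account rests on a few compounds, and the source may have more. Where it says the series, first, only, none or still open, it means among the compounds named here.

Of the compounds shown here, three built on one shared core have been measured in a functional assay on PC-3 cells (Homo sapiens) for antiproliferative activity, read by MTT assay, with a stated time of 72 h; on this read-out lower numbers stand for stronger inhibition and higher numbers for weaker inhibition. Compound 1 `C/C(=N\NC(=O)c1cccc(S(=O)(=O)N2CCOCC2)c1)c1cccc(O)c1` reaches only a limit of the assay, (the limit of > 100000 nM in this assay, at which 1 of the 3 values shown sits), and is recorded as > 100000 nM. Compound 2 `CCN(CC)c1ccc(/C=N/NC(=O)c2cccc(S(=O)(=O)N3CCOCC3)c2)c(O)c1` gives 14000 nM. Compound 3 `COc1ccc(/C=N/NC(=O)c2cccc(S(=O)(=O)N3CCOCC3)c2)c(O)c1` gives 5800 nM, the lowest of the two numbers shown, and the step of a 2.4-fold lower number from compound 2 to compound 3 (0.38 log units; beyond the scatter) is modest. Compound 4 `O=C(N/N=C/c1cc(Br)ccc1O)c1cccc(S(=O)(=O)N2CCOCC2)c1` has not yet been measured; it differs from compound 3 by 5-bromo-2-hydroxyphenyl in place of 2-hydroxy-4-methoxyphenyl on a carbon with a double bond to nitrogen. No measured step swaps this whole ring fragment, and the only step shown, a 2.4-fold lower number from compound 2 to compound 3 (0.38 log units; beyond the scatter), changed a group on that ring by a modest amount. Compound 4 is therefore expected to give 5000 nM, within 1500 nM to 20000 nM. The step of a 1.2-fold lower number from compound 3 to compound 4 (0.06 log units; within the scatter) is expected to stay near the usual scatter.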

Compound 4, half-maximal inhibitory concentration: 7230 nM
Estimate against measurement, compound 4: 1.4-fold (0.16 log units) below, within the range that was stated.
By their numbers in this assay, from the lowest: compounds 3, 4 and 2 (each within the scatter of the next, the first and the last beyond it). At a limit, above all of these: compound 1.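

In this assay, a 1.2-fold higher number from compound 3 to compound 4 (0.10 log units; within the scatter) shows that the whole ring fragment on this carbon can be exchanged, with 5-bromo-2-hydroxyphenyl entering for 2-hydroxy-4-methoxyphenyl, without moving the number beyond the scatter. A bromine and a methoxy group, each on a ring that keeps its hydroxy group, therefore cannot be told apart in this read-out. Nothing measured here offers an explanation for this result.

Still open, on these data alone, is what a ring without the hydroxy group would give. Also open, as far as these compounds go, is what a carboxylic acid or an amine on this ring would give.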